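Removing the hydroxy group from compound 2

This account rests on a few compounds, and the source may have more. Where it says the series, first, only, none or still open, it means among the compounds named here.

- Compound 1 `COc1ccc(C2C(O)C(=O)N2c2cc(OC)c(OC)c(OC)c2)cc1O`: 463 nM
- Compound 2 `CCOc1ccc(C2C(O)C(=O)N2c2cc(OC)c(OC)c(OC)c2)cc1`: 15 nM
- Compound 3 `COc1cc(N2C(=O)C(O)C2c2ccc(SC)cc2)cc(OC)c1OC`: 15 nM

In a functional assay on HT-29 cells (Homo sapiens) for inhibition, read by sulforhodamine B assay, with a stated time of 72 h (a lower number here means a stronger inhibitor, a higher number a weaker inhibitor), compound 2 shares the lowest number of the three with compound 3, no change at the digits printed from compound 2 to compound 3 (within the scatter). Compound 4 `CCOc1ccc(C2CC(=O)N2c2cc(OC)c(OC)c(OC)c2)cc1` differs from compound 2 at one place: hydrogen in place of hydroxy on a saturated ring carbon. Within the data shown here, the measured steps of a 31-fold lower number from compound 1 to compound 2 (1.49 log units; beyond the scatter) and a 31-fold lower number from compound 1 to compound 3 (1.49 log units; beyond the scatter) were large, but both replace the 3-hydroxy-4-methoxyphenyl group, and no measured pair loses the hydroxy. Among the measured compounds shown here, they show only that one change can matter greatly here. Compound 2 already stands at 15 nM, so a moderate rise is expected, with wide uncertainty. The expected change is a 4.0-fold higher number from compound 2 to compound 4 (0.60 log units; beyond the scatter). For compound 4 the estimated value is 60 nM, with an expected range of 10 nM to 400 nM.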

Compound 4, half-maximal inhibitory concentration: 65 nM
The estimate for compound 4 lay 1.1-fold (0.03 log units) below the measured number; the range from low to high includes it.
By their numbers in this assay, from the lowest: compounds 2 and 3 (each within the scatter of the next); then compound 4; then compound 1.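

Among these compounds, compound 2 and compound 4 are the first pair to differ only at this saturated ring carbon, and in this assay losing the hydroxy gives a 4.3-fold higher number from compound 2 to compound 4 (0.64 log units; beyond the scatter) as a modest but real change. The hydroxy therefore contributes here, yet compound 4 still reads 65 nM without it. Nothing available explains this difference.

As far as these compounds go, it remains open whether an amine or a carboxylic acid on this carbon would match the hydroxy. Whether the same step holds alongside the 4-(methylsulfanyl)phenyl group of compound 3 is also unknown.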